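This account rests on a few compounds, and the source may have more. Where it says the series, first, only, none or still open, it means among the compounds named here.

Measured compounds:
- compound 1, `COc1ccc(Cn2cc[nH]c2=S)cc1`: 204000 nM
- compound 2, `S=c1[nH]ccn1Cc1cc(Cl)cc(Cl)c1`: 2400 nM

In an assay on isolated protein for inhibition of Dopamine beta-hydroxylase (Rattus norvegicus) (a higher number here means a weaker inhibitor, a lower number a stronger inhibitor), compound 2 gives the lower of the two numbers, and compound 1 gives 204000 nM, a gap that lies well beyond the usual scatter, so compound 2 is the stronger inhibitor of the pair. Compound 3, `COc1c(Cl)cc(Cn2cc[nH]c2=S)cc1Cl`, has not been measured in this assay. It differs from compound 2 in one place: methoxy in place of hydrogen on an aromatic carbon. Within the data shown here, no measured pair shows this exact change, so its effect is not known from the data at hand. The expectation is that the step from compound 2 to compound 3 in this assay is modest, a 1.9-fold higher number from compound 2 to compound 3 (0.27 log units; within the scatter), toward a somewhat higher number, since compound 2 already gives 2400 nM and compound 1 with its own methoxy gives the far weaker 204000 nM. Compound 3 is therefore estimated at 4500 nM, in a range from 1500 nM to 15000 nM.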

Compound 3, half-maximal inhibitory concentration: 46800 nM
Beside the measured number, compound 3's estimate is 10-fold (1.02 log units) below it; measured number outside the range, above it.
By their numbers in this assay, from the lowest: compound 2; then compound 3; then compound 1.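

In this assay, among these compounds, methoxy in place of hydrogen on the aromatic carbon ortho to two chloro groups and para to a group of 7 heavy atoms gives a 20-fold higher number from compound 2 to compound 3 (1.29 log units; beyond the scatter) and is the first change that can be read on its own. It shows that this carbon is not indifferent to substitution: with both chloro groups kept, the added methoxy alone leaves a clearly weaker inhibitor. No measurement shown accounts for the size of this step.

Whether the loss belongs to methoxy itself or to any group on this carbon stays open, as a hydroxyl, a fluorine or a methyl group there does not appear among the compounds shown. Also open, from the compounds shown here alone, is whether the two chloro groups influence the size of the step, as compound 1 differs from compound 3 in more than one place.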